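This account rests on a few compounds, and the source may have more. Where it says the series, first, only, none or still open, it means among the compounds named here.

In a functional assay on MCF7 cells (Homo sapiens) for cytotoxicity, read by MTT assay, with a stated time of 48 h (a higher number here means a weaker inhibitor, a lower number a stronger inhibitor), compound 3 (`N#Cc1ccc(OCc2nnc(-c3ccccc3)o2)cc1F`) gives > 50000 nM as its reading. This reading is a limit of the assay and not a number.

Compound 4 (`N#Cc1ccc(OCc2nnc(-c3ccc(F)cc3)o2)cc1F`) has fluoro in place of hydrogen on an aromatic carbon, so that phenyl becomes 4-fluorophenyl (fluoro in place of hydrogen on an aromatic carbon). Among the compounds with values here, only one measured step bears on this swap, and it comes from a different pair of compounds and a different halogen. Compound 1 (`COc1cc(C#N)ccc1OCc1nnc(-c2ccccc2)o1`) gives 32200 nM in this assay as its reading. Compound 2 (`COc1cc(C#N)ccc1OCc1nnc(-c2ccc(Cl)cc2)o1`) gives 21500 nM in the same test, with chloro in place of hydrogen on an aromatic carbon.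

Within the data shown here, with that single step (a 1.5-fold lower number from compound 1 to compound 2 (0.18 log units; within the scatter)) as the only guide, no step beyond the scatter is expected in this assay in either direction. One step with chloro is a thin basis for a swap to fluoro, so this expectation is a loose one. The expected step (an at least 1.1-fold lower number from compound 3 to compound 4 (0.04 log units; that floor lies within the scatter)) is only an estimate and stays within the usual scatter. A reading that is again only a limit would fit this expectation too. For compound 4 the estimated value is 45000 nM with an expected range from 18000 nM to 90000 nM in this test.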

Compound 4, half-maximal inhibitory concentration: 20500 nM
The estimate for compound 4 lay 2.2-fold (0.34 log units) above the measured number; low and high end bracket the measured number.
By their numbers in this assay, from the lowest: compounds 4, 2 and 1 (each within the scatter of the next). At a limit, above all of these: compound 3.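

In this assay, changing phenyl to 4-fluorophenyl gives an at least 2.4-fold lower number from compound 3 to compound 4 (0.38 log units; beyond the scatter), so a single fluoro at this place on the ring can shift the reading by more than the usual scatter. The earlier chloro swap gave only a 1.5-fold lower number from compound 1 to compound 2 (0.18 log units; within the scatter), which left open whether a halogen here had any visible effect, although that step comes from a different core and a different halogen. Compound 3 reads only as a limit, so the step to compound 4 gives a minimum size and its full size remains unknown: the limit of > 50000 nM in this assay, at which 1 of the 4 values shown sits.

As far as these compounds go, the two steps differ in both halogen and core, so it remains open whether fluoro would have the same effect on the core of compound 1, or chloro on the core of compound 3. From the compounds shown here alone, it is also open how the reading would respond to a group of another kind at this place on the ring, such as an amine or a carboxylic acid.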